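The source may report more compounds than this note shows. Statements on the series, on what has been measured and on what is new or still open speak of the compounds shown alone.

Compound 1 `C#CCOc1ccc2cc(C(=O)OC)c(=O)oc2c1` is the starting point of this set: in an assay on cells for inhibition of Amine oxidase [flavin-containing] A (Homo sapiens), read by Amplex Red, with stated times of 30 min and 45 min (a higher number here means a weaker inhibitor, a lower number a stronger inhibitor), compound 1 gives 1570 nM. Compound 2 `C#CCCOc1ccc2cc(C(=O)OC)c(=O)oc2c1` carries propargyl in place of ethynyl on a saturated chain carbon bound to an oxygen on an aromatic ring, and in this assay compound 2 gives 818 nM, which amounts to a 1.9-fold lower number from compound 1 to compound 2 (0.28 log units; within the scatter). Compound 3 `C#CCCCOc1ccc2oc(=O)c(C(=O)OC)cc2c1` has a core whose difference from the core of compound 1 is not broken down here. In this assay compound 3 reaches only a limit of the assay, > 10000 nM, as noted by the limit of > 10000 nM in this assay, at which 1 of the 3 values shown sits. Compound 4 `C#CCCCCOc1ccc2oc(=O)c(C(=O)OC)cc2c1` shows the same kind of change as propargyl in place of ethynyl on a saturated chain carbon bound to an oxygen on an aromatic ring, namely (propargyl in place of ethynyl on a saturated chain carbon, three bonds along the chain from an oxygen on an aromatic ring), though here the place is three bonds along the chain from the oxygen rather than bound to it. Since compound 3 stands at a limit and the earlier step was within the scatter, compound 4 is expected to stay weak, with a step that the limit leaves unreadable from compound 3 to compound 4 as the estimated step. The estimate for compound 4 is 15000 nM, between 5000 nM and 50000 nM.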

Compound 4, half-maximal inhibitory concentration: > 10000 nM
Compound 4 gave a limit, no number; the forecaster's own chance of this, stated with the estimate: 70%; the middle value lies beyond the limit too.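

In this assay, among these compounds, compound 3 and compound 4 both stand at a limit, not a number, so no step between them can be read: the limit of > 10000 nM in this assay, at which 2 of the 4 values shown sit. The compounds shown leave open whether pent-4-yn-1-yl and hex-5-yn-1-yl differ at all.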